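Notes on the amide-to-aminopyridine step in the series

This account rests on a few compounds, and the source may have more. Where it says the series, first, only, none or still open, it means among the compounds named here.

The three measured compounds share a core and differ only in what sits on the amide carbonyl. Compound 1 `CC(O)c1ccc(C(=O)N[C@@H](C)Cn2ccc(-c3ccc(C#N)c(Cl)c3)n2)cc1` gives 3690 nM in a functional assay on LNCaP cells (Homo sapiens) for antiproliferative activity, read by CCK-8 assay, with a stated time of 6 days; a lower number here means a stronger inhibitor, a higher number a weaker inhibitor. Compound 2 `CC(=O)c1ccc(C(=O)N[C@@H](C)Cn2ccc(-c3ccc(C#N)c(Cl)c3)n2)cc1` gives 3600 nM, and compound 3 `C[C@@H](Cn1ccc(-c2ccc(C#N)c(Cl)c2)n1)NC(=O)C1CC(=O)C1` gives 3040 nM. The steps are a 1.0-fold lower number from compound 1 to compound 2 (0.01 log units; within the scatter), a 1.2-fold lower number from compound 1 to compound 3 (0.08 log units; within the scatter) and a 1.2-fold lower number from compound 2 to compound 3 (0.07 log units; within the scatter); compound 3 holds the lowest of the three numbers, but each of its steps to the others lies within the scatter, so the three stand level.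

Compound 4 `C[C@@H](Cn1ccc(-c2ccc(C#N)c(Cl)c2)n1)Nc1ccncc1` is not yet measured. The change from compound 3 is pyridin-4-yl in place of (3-oxocyclobutyl)carbonyl on an amine nitrogen. For the measured compounds named here, none of the measured steps touches this position: all three vary the group on the carbonyl carbon while keeping the amide, and all three were within the scatter. Going by the values given here, there is thus no step that bears directly on the change, and the flat set gives no direction. The expectation for compound 4 is a 1.0-fold lower number from compound 3 to compound 4 (0.01 log units; within the scatter), with the range kept broad for lack of any bearing step. Compound 4 is estimated at 3000 nM, between 700 nM and 13000 nM.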

Compound 4, half-maximal inhibitory concentration: 2560 nM
The estimate for compound 4 lay 1.2-fold (0.07 log units) above the measured number; low and high end bracket the measured number.
By their numbers in this assay, from the lowest: compounds 4, 3, 2 and 1 (each within the scatter of the next).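

Setting pyridin-4-yl in place of (3-oxocyclobutyl)carbonyl on the amine nitrogen gives, in this assay, a 1.2-fold lower number from compound 3 to compound 4 (0.07 log units; within the scatter). For the compounds shown here, this is the first step to remove the amide carbonyl rather than vary the group on it, and for this pair, the loss of that carbonyl leaves the number within the scatter. An aromatic ring carried directly on the amine nitrogen thus stands level with the (3-oxocyclobutyl)carbonyl, and no measurement here accounts for that.

Going by these compounds, whether a phenyl or a pyridin-3-yl on the same amine nitrogen would also stand level remains open. So does the plain primary amine, with no group on that nitrogen at all, which would show whether the pyridin-4-yl contributes to the number.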